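Swapping 3,4-dichlorophenyl for 4-bromophenyl

This account rests on a few compounds, and the source may have more. Where it says the series, first, only, none or still open, it means among the compounds named here.

In a functional assay on MCF7 cells (Homo sapiens) (a lower number here means a stronger inhibitor of growth, a higher number a weaker inhibitor of growth), compound 3 `O=S(=O)(/C=C/c1ccc(Cl)c(Cl)c1)Cc1ccc(Nc2ncnc3ccccc23)cc1` gives 28000 nM and compound 1 `O=S(=O)(/C=C/c1ccc(F)cc1)Cc1ccc(Nc2ncnc3ccccc23)cc1` gives 16000 nM. These two sit level, as a 1.8-fold higher number from compound 1 to compound 3 (0.24 log units; within the scatter) lies within the scatter. Compound 2 `N#Cc1ccc(/C=C/S(=O)(=O)Cc2ccc(Nc3ncnc4ccccc34)cc2)cc1` reads > 100000 nM, which is a limit of the assay. Placing 4-cyanophenyl on the chain gave larger steps, beyond the scatter: an at least 6.2-fold higher number from compound 1 to compound 2 (0.79 log units; beyond the scatter) and an at least 3.5-fold lower number from compound 2 to compound 3 (0.55 log units; beyond the scatter).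

Compound 4 `O=S(=O)(/C=C/c1ccc(Br)cc1)Cc1ccc(Nc2ncnc3ccccc23)cc1`, not yet measured, carries 4-bromophenyl in place of 3,4-dichlorophenyl on a double-bonded chain carbon bound to a double-bonded chain carbon. It has no cyano group, so the closest guide is the small step of a 1.8-fold higher number from compound 1 to compound 3 (0.24 log units; within the scatter). The expected change is a 1.4-fold lower number from compound 3 to compound 4 (0.15 log units; within the scatter), which would stay within the scatter. Compound 4 is estimated at 20000 nM, with an expected range of 8000 nM to 50000 nM.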

Compound 4, concentration for 50% growth inhibition: 91000 nM
The estimate for compound 4 lay 4.6-fold (0.66 log units) below the measured number, and the stated range ends below it.
By their numbers in this assay, from the lowest: compounds 1 and 3 (each within the scatter of the next); then compound 4. At a limit, above all of these: compound 2.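

In this assay, the halogen groups at this place are not interchangeable: 4-bromophenyl gives a weaker inhibitor of growth than either halogen-bearing neighbour, with a 3.3-fold higher number from compound 3 to compound 4 (0.51 log units; beyond the scatter) and a 5.7-fold higher number from compound 1 to compound 4 (0.75 log units; beyond the scatter). Earlier, only 4-cyanophenyl had given steps beyond the scatter here, so a change of halogen alone can also do so. Compound 2 stands at a limit: the limit of > 100000 nM in this assay, at which 1 of the 4 values shown sits. With an at least 1.0-fold lower number from compound 2 to compound 4 (0.04 log units; that floor lies within the scatter) the step is only a floor and shows no change beyond the scatter.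

Going by these compounds, it remains open whether 4-chlorophenyl or 4-methoxyphenyl at this place would read nearer compound 1 or compound 4. The compounds shown do not tell why bromo reads higher than fluoro.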